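Fluoropyridinyl for phenyl on the five-membered ring: compound 3

The compounds below may be only part of what the source reports. "The series", "measured", "known", "first", "only" and "open" are said of these compounds alone.

Compound 1 `Cc1cc(NC(=O)Cn2nnc(-c3ccccc3)n2)n(C2CCCCC2)n1` has been measured in an assay on HEK293 cells for activation of Kir3.1/Kir3.2 (Homo sapiens), read by thallium flux (on this read-out lower numbers stand for smaller maximal responses and higher numbers for larger maximal responses), where compound 1 gives 92%. Of the two numbers in hand this is the highest; the nearest is compound 2 `Cc1cc(NC(=O)Cn2nnc(-c3ccccc3)n2)n(C2CCC(F)(F)CC2)n1`, which in this assay gives 68%. For the measured compounds named here, the one step between measured compounds, a number 24 percentage points lower from compound 1 to compound 2 (beyond the scatter), arises from 4,4-difluorocyclohexyl in place of cyclohexyl on an aromatic nitrogen.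

Compound 3 `Cc1cc(NC(=O)Cn2nnc(-c3cccc(F)n3)n2)n(C2CCCCC2)n1` differs from compound 1 at a different place: 6-fluoropyridin-2-yl in place of phenyl on an aromatic carbon. Going by the values given here, no measured pair alters the group on the aromatic carbon of the five-membered aromatic ring with 4 nitrogen, so the step from compound 1 to compound 2 bears on compound 3 only in showing that a single change at the edge of the shared core can move the largest response beyond the scatter. With nothing closer to go on, the expectation for compound 3 in this assay is a step within the scatter, a number 7 percentage points lower from compound 1 to compound 3 (within the scatter), with wide room on either side. Compound 3 is estimated at 85%, between 60% and 105%.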

Compound 3, largest response reached (Emax), in percent of the reference or control that the assay uses: > 83%
Compound 3: a limit, no number; the forecaster's own chance of this, stated with the estimate: 0%; the middle value lies beyond the limit too.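

In this assay, for the compounds shown here, compound 3 gives > 83%, which is a limit and not a number, so no step from compound 1 to compound 3 can be read. The compounds shown leave open whether 6-fluoropyridin-2-yl in place of phenyl on an aromatic carbon moves the largest response beyond the scatter, and in which direction.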